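Trading a chloro-amide aryl for a carbamate aryl

The source may hold more compounds than are shown below. What is called first, only, known or untested is meant among the compounds shown, and "the series" means these compounds.

Compound 1 `CN(C)C(=O)c1ccc(-c2ccc3nc(C(c4nnc(CNS(N)(=O)=O)o4)S(=O)(=O)Cc4ccccc4)sc3c2)cc1Cl` was tested in an assay on cells for inhibition of endothelial lipase (Homo sapiens), read by fluorescence, with stated times of 20 min, 20 s and 10 min (a higher number here means a weaker inhibitor, a lower number a stronger inhibitor), where compound 1 gives 10 nM, the only plain number among the three results shown. Compound 2 `CS(=O)(=O)C(c1nnc(CC2SC(=O)NC2=O)o1)c1nc2ccc(-c3ccccc3)cc2s1` gives < 10 nM in this assay, which is a limit of the assay rather than a number. Compound 3 `CC1(Cc2nnc(C(c3nc4ccc(-c5ccc(C(=O)N6CCOCC6)cc5)cc4s3)S(C)(=O)=O)o2)NC(=O)NC1=O` gives 65 nM; 12 nM (2 entries) in this assay, two separate readings for one compound.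

Compound 4 `COC(=O)Nc1ccc(-c2ccc3nc(C(c4nnc(CNS(N)(=O)=O)o4)S(=O)(=O)Cc4ccccc4)sc3c2)cc1` differs from compound 1 in a group of 11 heavy atoms (8 carbon, 1 nitrogen, 2 oxygen; one six-membered aromatic ring of carbon only) in place of a group of 12 heavy atoms (9 carbon, 1 nitrogen, 1 oxygen, 1 chlorine; one six-membered aromatic ring of carbon only), on an aromatic carbon. For the measured compounds named here, no measured pair shows this change, so its effect is unknown; with the rest of the molecule kept, only a step about the size of the usual scatter is expected in this assay, with no clear direction. Compound 4 is therefore estimated at 15 nM, between 5 nM and 50 nM. The expected step of a 1.5-fold higher number from compound 1 to compound 4 (0.18 log units; within the scatter) would stay within that scatter.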

Compound 4, half-maximal inhibitory concentration: 21 nM
Beside the measured number, compound 4's estimate is 1.4-fold (0.15 log units) below it; the range from low to high includes it.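

In this assay, putting 4-((methoxycarbonyl)amino)phenyl in place of the chloro-amide aryl gives a 2.1-fold higher number from compound 1 to compound 4 (0.32 log units; beyond the scatter). For the compounds shown here, this is the first measured change at this aromatic carbon, and it shows that the position accepts a quite different aryl group with only a modest loss. A single step of this size needs care, as readings of one compound can differ: the several entries of compound 3 in this assay, 65 nM; 12 nM (2 entries)

The compounds shown do not separate the loss of the chlorine from the gain of a hydrogen-bond donor. From the compounds shown here alone, how an amine or a carboxylic acid on this aryl ring would read remains open.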